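From 4-Cyanophenyl to 3,5-Dimethoxyphenyl

The compounds below may be only part of what the source reports. "The series", "measured", "known", "first", "only" and "open" are said of these compounds alone.

Among the measured compounds shown here, in an ADME assay on L02 cells (Homo sapiens) for cytotoxicity, read by MTT assay, with a stated time of 24 h (a higher number here means a weaker inhibitor, a lower number a stronger inhibitor), compound 1 `CC(=O)Nc1ccc(S(=O)(=O)N2C/C(=C\c3cccc([N+](=O)[O-])c3)C(=O)/C(=C/c3ccccc3F)C2)cc1` gives 18400 nM and compound 2 `CC(=O)Nc1ccc(S(=O)(=O)N2C/C(=C\c3ccc(C#N)cc3)C(=O)/C(=C/c3ccccc3F)C2)cc1` gives 14400 nM, so compound 2 stands level with its only measured neighbour. Compound 3 `COc1cc(/C=C2\CN(S(=O)(=O)c3ccc(NC(C)=O)cc3)C/C(=C\c3ccccc3F)C2=O)cc(OC)c1` is still unmeasured and differs from compound 2 by one group: 3,5-dimethoxyphenyl in place of 4-cyanophenyl on a double-bonded chain carbon bound to a double-bonded ring carbon. For the measured compounds named here, the one measured step bearing on this, a 1.3-fold lower number from compound 1 to compound 2 (0.11 log units; within the scatter), exchanged a group at the same place and stayed within the scatter. A similarly small result is therefore expected in this assay, with the estimated step, a 1.1-fold higher number from compound 2 to compound 3 (0.05 log units; within the scatter), also within the scatter. For compound 3 the estimate is 16000 nM, with an expected range of 8000 nM to 32000 nM.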

Compound 3, half-maximal inhibitory concentration: 15400 nM
For compound 3 the middle estimate is 1.0-fold (0.02 log units) above the measured one; low and high end bracket the measured number.
By their numbers in this assay, from the lowest: compounds 2, 3 and 1 (each within the scatter of the next).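

In this assay, 3,5-dimethoxyphenyl on a double-bonded chain carbon bound to a double-bonded ring carbon gives a 1.1-fold higher number from compound 2 to compound 3 (0.03 log units; within the scatter) and a 1.2-fold lower number from compound 1 to compound 3 (0.08 log units; within the scatter) as its two steps. Three differently substituted phenyl rings therefore read level at this place, so the exchange of the earlier pair now extends to a group carrying methoxy substituents instead of a nitrile or a nitro group. No measurement available here accounts for this. Going by these compounds, all three groups are phenyl rings, so the effect of an amine, a carboxylic acid or a longer chain at this place remains open.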